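The source may report more compounds than this note shows. Statements on the series, on what has been measured and on what is new or still open speak of the compounds shown alone.

In a functional assay on T-24 cells (Homo sapiens) for antiproliferative activity, read by MTT assay, with a stated time of 48 h (on this read-out lower numbers stand for stronger inhibition and higher numbers for weaker inhibition), compound 1 `O=C(Nc1ccccc1)Nc1cccc(CNc2nccnc2Cl)c1` gives 19800 nM. In this assay compound 2 `COc1ccccc1NC(=O)Nc1cccc(CNc2nccnc2Cl)c1` gives 10400 nM, and in this assay compound 3 `Cc1ccccc1NC(=O)Nc1cccc(CNc2nccnc2Cl)c1` gives 13600 nM. Among these three numbers compound 3 holds the second highest, yet the step of a 1.5-fold lower number from compound 1 to compound 3 (0.16 log units; within the scatter) and the step of a 1.3-fold higher number from compound 2 to compound 3 (0.12 log units; within the scatter) both lie within the scatter, as does a 1.9-fold lower number from compound 1 to compound 2 (0.28 log units; within the scatter), so the three compounds cannot be told apart on these data. Compound 4 `Cc1ccc(NC(=O)Nc2cccc(CNc3nccnc3Cl)c2)cc1` differs from compound 3 by 4-methylphenyl in place of 2-methylphenyl on an amide-type nitrogen. Among the compounds with values here, none of the measured steps bears directly on this exchange: each of them adds a methoxy or a methyl to an aromatic carbon or swaps one for the other, and none exchanges a 2-methylphenyl for a 4-methylphenyl; all three remained within the scatter. Compound 4 is therefore expected to show no step beyond the scatter in this assay, that is a 1.1-fold lower number from compound 3 to compound 4 (0.05 log units; within the scatter). The estimate for compound 4 in this assay is 12000 nM, expected to fall between 5000 nM and 30000 nM.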

Compound 4, half-maximal inhibitory concentration: 9820 nM
Compound 4: the middle estimate sits 1.2-fold (0.09 log units) above what was measured, and the stated range covers the measured number.
By their numbers in this assay, from the lowest: compounds 4, 2, 3 and 1 (each within the scatter of the next).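

In this assay, within the data shown here, the exchange of 2-methylphenyl for 4-methylphenyl on the amide-type nitrogen, which none of the earlier compounds tested, gives a 1.4-fold lower number from compound 3 to compound 4 (0.14 log units; within the scatter) and so does not separate these two placements of the methyl on these data. The comparisons that include the 2-methoxyphenyl and unsubstituted phenyl compounds, a 1.1-fold lower number from compound 2 to compound 4 (0.02 log units; within the scatter) and a 2.0-fold lower number from compound 1 to compound 4 (0.30 log units; within the scatter), also remain within the scatter, so even with this fourth compound, none of the groups at this position can be told apart. No supporting evidence bears on this result.

What the compounds shown leave open is whether any group at this position can move the number beyond the scatter. A carboxylic acid, an amine or a trifluoromethyl on this phenyl ring in place of the methyl would address that question, and the same holds for a longer chain such as butyl.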